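A few compounds are considered here, and "the series" means these few. Any claim that something is new, unique, unknown or untested is made for them only; others in the source may bear on it.

Measured so far:
Compound 1 `COc1cc(Cl)cc(-c2nn(-c3cccc(NC(=O)c4ccc(Cl)c(Cl)c4)c3)cc2-c2ccncc2)c1`: 68.9%
Compound 2 `COc1cc(Cl)cc(-c2nn(-c3cccc(NC(=O)Nc4cc(C(F)(F)F)cc(C(F)(F)F)c4)c3)cc2-c2ccncc2)c1`: 1.22%

In a functional assay on M14 cells (Homo sapiens) for inhibition, read by sulforhodamine B assay, with a stated time of 48 h, tested at 10 uM (a higher number here means a weaker effect of the compound at the concentration tested, a lower number a stronger effect), compound 1 gives 68.9%, while compound 2 gives 1.22%. Compound 2 thus shows the lowest number of the two, and its nearest neighbour, compound 1, sits far higher, a gap well beyond the usual scatter. Going by the values given here, compound 1 and compound 2 differ in more than one place, so no single step between measured compounds can be read from them.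

Compound 3 `COc1cc(Cl)cc(-c2nn(-c3cccc(NC(=O)Nc4cccc(C(F)(F)F)c4)c3)cc2-c2ccncc2)c1` is not yet measured. It differs from compound 2 in this way: hydrogen in place of trifluoromethyl on an aromatic carbon. Among the compounds with values here, with no measured step of this kind to lean on, the expectation is a moderate rise in the number, that is, a weaker effect than compound 2, yet one still far from the level of compound 1. The estimated step is a number 16.8 percentage points higher from compound 2 to compound 3 (beyond the scatter). For compound 3 the expected value is 18%, within a range from 2% to 50%.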

Compound 3, a percentage reported as activity, at one concentration (the size of the read-out at that concentration, not a potency): 9.99%
Estimate against measurement, compound 3: 8 percentage points above; the measured number falls inside the stated range.
By their numbers in this assay, from the lowest: compounds 2 and 3 (each within the scatter of the next); then compound 1.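

In this assay, hydrogen in place of trifluoromethyl on this aromatic carbon gives a number 8.8 percentage points higher from compound 2 to compound 3 (within the scatter) and so leaves compound 2 and compound 3 indistinguishable, which means that a strong effect at the tested concentration does not depend on this trifluoromethyl group. Compound 3 also turns the earlier multi-place contrast into a single step: (3-(trifluoromethyl)phenyl)amino in place of 3,4-dichlorophenyl on a carbonyl carbon gives a number 58.9 percentage points lower from compound 1 to compound 3 (beyond the scatter) in this assay, a large change among these compounds. No measurement offers a reason for either step.

Going by these compounds, it remains open whether the remaining trifluoromethyl group could also give way to hydrogen, or whether an amine or a carboxylic acid would be tolerated on this ring. The large step also swaps two things at once, so the share of the added amino link and that of the changed ring cannot yet be separated.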